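From a fluorophenyl to a thiophene on the shared core

The compounds below may be only part of what the source reports. "The series", "measured", "known", "first", "only" and "open" are said of these compounds alone.

Compound 2 `Fc1ccc(-c2cn3ccnc3c(-c3ccc4ncn(C5CCCCC5)c4c3)n2)cc1` stands highest of the two compounds measured in a functional assay on RPMI-8226 cells (Homo sapiens) for inhibition, read by sulforhodamine B assay, with a stated time of 48 h, tested at 10 uM (a lower number here means less inhibition, a higher number more inhibition at the concentration tested (going by the name of the read-out)), where compound 2 gives 50.1%. Among the measured compounds shown here, its only neighbour, compound 1 `Brc1cn2ccnc2c(-c2ccc3ncn(C4CCCCC4)c3c2)n1`, gives 14.9% in this assay. For the measured compounds named here, the single step known connects them: a number 35.2 percentage points higher from compound 1 to compound 2 (beyond the scatter). Compound 3 `c1cn2cc(-c3ccsc3)nc(-c3ccc4ncn(C5CCCCC5)c4c3)c2n1` has not yet been measured in this assay; it differs from compound 2 in one place: thiophen-3-yl in place of 4-fluorophenyl on an aromatic carbon. Going by the values given here, no measured step swaps one aromatic ring for another, so the step from compound 1 to compound 2 bears on it only indirectly, as it shows a large rise when an aromatic ring replaces bromo at this place. Because compound 2 gives 50.1% with such a ring present, compound 3 is expected to keep much of that inhibition, with a modest downward step a number 10.1 percentage points lower from compound 2 to compound 3 (beyond the scatter) that may lie within the scatter. Compound 3 is estimated at 40% in this assay, between 20% and 60%.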

Compound 3, a percentage reported as inhibition, at one concentration (the size of the read-out at that concentration, not a potency): 37.9%
The estimate for compound 3 lay 2.1 percentage points above the measured number; the range from low to high includes it.
By their numbers in this assay, from the lowest: compound 1; then compound 3; then compound 2.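

In this assay, replacing 4-fluorophenyl with thiophen-3-yl gives a number 12.2 percentage points lower from compound 2 to compound 3 (beyond the scatter) and so shows that the number at this place depends on which aromatic ring is present, not only on there being one. Thiophen-3-yl in place of bromo still gives a number 23 percentage points higher from compound 1 to compound 3 (beyond the scatter) and so the rise over bromo now appears with two different aromatic rings, one six-membered and one five-membered. Nothing at hand accounts for the gap between these two rings.

The compounds shown leave open how a pyridin-3-yl ring, a thiophen-2-yl ring or a phenyl ring without fluorine would read at this place. They also leave open whether a non-aromatic group there, such as an amine or a short alkyl chain, would retain any of the rise seen with the aromatic rings.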